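Phenyl in place of nitro on the hydrazone aryl ring

This account rests on a few compounds, and the source may have more. Where it says the series, first, only, none or still open, it means among the compounds named here.

Compound 2 `CC1CC/C(=N\Nc2ccc([N+](=O)[O-])cc2)c2ncc(C(=O)O)c(=O)n21` gives 0.8 umol/kg in a functional assay on the whole organism for inhibition, with Rattus norvegicus as the target (on this read-out lower numbers stand for an effect already at smaller amounts and higher numbers for an effect only at larger amounts of compound), the lower of the two numbers seen so far, though with a 1.6-fold lower number from compound 1 to compound 2 (0.21 log units; within the scatter) the gap to compound 1 `Cc1ccc(N/N=C2\CCC(C)n3c2ncc(C(=O)O)c3=O)cc1`, which gives 1.3 umol/kg, is within the scatter. Compound 3 `CC1CC/C(=N\Nc2ccc(-c3ccccc3)cc2)c2ncc(C(=O)O)c(=O)n21` differs from compound 2 by phenyl in place of nitro on an aromatic carbon. Among the measured compounds shown here, the only step bearing on this position was within the scatter, so no step beyond the scatter is expected in this assay. Compound 3 is therefore estimated at 1.1 umol/kg, between 0.3 umol/kg and 4 umol/kg. The expected step is a 1.4-fold higher number from compound 2 to compound 3 (0.14 log units; within the scatter).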

Compound 3, dose for 50% inhibition: 1.1 umol/kg
Compound 3: middle estimate and measured number agree at the digits printed; the range from low to high includes it.
By their numbers in this assay, from the lowest: compounds 2, 3 and 1 (each within the scatter of the next).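

In this assay, the place on the six-membered aromatic ring, para to a large group, now holds three different groups, and the read-out stays within the scatter with each. Phenyl brings six heavy atoms and a second aromatic ring where nitro has three and no ring, yet the steps are a 1.4-fold higher number from compound 2 to compound 3 (0.14 log units; within the scatter) and a 1.2-fold lower number from compound 1 to compound 3 (0.07 log units; within the scatter) only. Nothing available explains this flat result. From the compounds shown here alone, whether an amine, a carboxylic acid or a longer chain at this place would move the number beyond the scatter remains open.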